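The source may hold more compounds than are shown below. What is called first, only, known or untested is meant among the compounds shown, and "the series" means these compounds.

Compound 1 `C=CCNC(=C\C(=O)/C=C/c1ccc(O)c(OC)c1)/C=C/c1ccc(O)c(OC)c1` gives > 25000 nM
Compound 2 `COc1cc(/C=C/C(=O)/C=C(/C=C/c2ccc(OC(C)=O)c(OC)c2)NCC(C)C)ccc1OC(C)=O` gives > 25000 nM
Compound 3 `CC(C)CNC(=C\C(=O)/C=C/c1ccc(O)cc1)/C=C/c1ccc(O)cc1` gives 20100 nM

In a functional assay on HT-29 cells (Homo sapiens) for inhibition, read by MTT assay, with a stated time of 72 h (a higher number here means a weaker inhibitor, a lower number a stronger inhibitor), compound 1 reaches only a limit of the assay, > 25000 nM, so no true number is known for it. Compound 2 also stops at a limit, > 25000 nM. Compound 3 alone gives a measured number, 20100 nM. Compound 1 therefore stands at the limit of > 25000 nM in this assay, at which 2 of the 3 values shown sit, and all three values point to weak inhibition. Compound 4 `CCCCNC(=C\C(=O)/C=C/c1ccc(O)c(OC)c1)/C=C/c1ccc(O)c(OC)c1` keeps the shared core and differs from compound 1 by propyl in place of vinyl on a saturated chain carbon bound to an amine nitrogen. For the measured compounds named here, no measured pair shows such a change, so the expected step that the limit leaves unreadable from compound 1 to compound 4 is none beyond the scatter, and compound 4 is estimated at 30000 nM, within 10000 nM to 100000 nM, most likely again a limit.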

Compound 4, half-maximal inhibitory concentration: 19700 nM
Estimate against measurement, compound 4: 1.5-fold (0.18 log units) above, within the range that was stated.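

Replacing allyl with butyl gives an at least 1.2-fold lower number from compound 1 to compound 4 (0.10 log units; that floor lies within the scatter). Compound 1 stands at a limit, so the true size of this step cannot be read: the limit of > 25000 nM in this assay, at which 2 of the 4 values shown sit. Even so, in this assay compound 4 gives a measured number, 19700 nM, which shows that a compound with a butyl chain in this place still inhibits only weakly.

The compounds shown leave open whether a longer chain, or a chain carrying a carboxylic acid or an amine, would move the number beyond the scatter.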